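The source may report more compounds than this note shows. Statements on the series, on what has been measured and on what is new or still open speak of the compounds shown alone.

In a functional assay on BaF3 cells (Mus musculus) for antiproliferative activity, read by CCK-8 assay and cell counting, with a stated time of 76 h (a higher number here means a weaker inhibitor, a lower number a stronger inhibitor), compound 1 `COc1cc2nccc(Oc3ccc(Nc4nn(C)cc4C(=O)Nc4ccc(F)cc4)cc3)c2cc1C(N)=O` gives 3060 nM and compound 2 `COc1cc2nccc(Oc3ccc(Nc4nn(C)cc4C(=O)Nc4ccccc4F)cc3)c2cc1C(N)=O` gives 1710 nM, so compound 2 stands level with compound 1 within the scatter. Compound 3 `COc1cc2nccc(Oc3ccc(Nc4nn(C)cc4C(=O)NOCc4ccccc4)cc3)c2cc1C(N)=O` follows from compound 2 with benzyloxy in place of 2-fluorophenyl on an amide-type nitrogen. Within the data shown here, the only measured step, a 1.8-fold lower number from compound 1 to compound 2 (0.25 log units; within the scatter), exchanges 4-fluorophenyl for 2-fluorophenyl. Among the measured compounds shown here, no measured compound carries benzyloxy, so the data give no direction, and no shift beyond the scatter is expected in this assay. The expected change is a 1.5-fold higher number from compound 2 to compound 3 (0.16 log units; within the scatter). Compound 3 is estimated at 2500 nM, with an expected range of 700 nM to 8000 nM.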

Compound 3, half-maximal inhibitory concentration: > 10000 nM
Compound 3 was reported as a limit; the forecaster's own chance of this, stated with the estimate: 5%; middle value at least 4.0-fold (0.60 log units) from the limit.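

Benzyloxy on the amide-type nitrogen brings the first change at this position that lies beyond the scatter in this assay (an at least 5.8-fold higher number from compound 2 to compound 3 (0.76 log units; beyond the scatter)) and (an at least 3.2-fold higher number from compound 1 to compound 3 (0.51 log units; beyond the scatter)). The exchange between the two fluorophenyl groups had shown no such separation. The entry for compound 3 is a limit, not a number, so the full size of both steps stays open: the limit of > 10000 nM in this assay, at which 1 of the 3 values shown sits.

Still open, on these data alone, is whether the oxygen of benzyloxy or the longer link to the ring carries the step, which a benzyl group on the same nitrogen would separate. Also open, as far as these compounds go, is how a methoxy group there would read.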